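The source may hold more compounds than are shown below. What is called first, only, known or untested is meant among the compounds shown, and "the series" means these compounds.

Measured compounds:
compound 1 `Cn1cc(-c2ccc3cn(Cc4ccc5ncccc5c4)nc3c2)cn1` — 106000 nM
compound 2 `CC(C)(C)[Si](C)(C)O[C@H]1CC[C@H](n2cc(-c3ccc4cn(Cc5ccc6ncccc6c5)nc4c3)cn2)CC1` — 1300000 nM

In a functional assay on MKN-45 cells (Homo sapiens) for cytotoxicity, read by Western blot, with a stated time of 1 h (a lower number here means a stronger inhibitor, a higher number a weaker inhibitor), compound 2 gives the highest of the two numbers; compound 1 gives a lower number, and that gap is beyond the scatter. Compound 3 `O[C@H]1CC[C@H](n2cc(-c3ccc4cn(Cc5ccc6ncccc6c5)nc4c3)cn2)CC1` differs from compound 2 by a hydrogen atom in place of a group of 7 heavy atoms (6 carbon, 1 silicon; no ring), on an oxygen on a saturated carbon. Within the data shown here, no measured pair shows this exact step. With the bulky silyl group gone, compound 3 is expected to move back toward compound 1, whose value is 106000 nM, so a step of a 4.3-fold lower number from compound 2 to compound 3 (0.64 log units; beyond the scatter) to a lower number is expected, beyond the scatter. Compound 3 is estimated at 300000 nM, with a range of 60000 nM to 1500000 nM.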

Compound 3, half-maximal inhibitory concentration: 13400 nM
Compound 3: the middle estimate sits 22-fold (1.35 log units) above what was measured; measured number below the stated range.
By their numbers in this assay, from the lowest: compound 3; then compound 1; then compound 2.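

In this assay, a hydrogen in place of the silicon-bearing group on the oxygen gives a large change (a 97-fold lower number from compound 2 to compound 3 (1.99 log units; beyond the scatter)), so what sits on this oxygen on a saturated carbon matters greatly. Compound 3 does more than return to the level of compound 1: 4-hydroxycyclohexyl in place of methyl on the aromatic nitrogen gives a modest further gain (a 7.9-fold lower number from compound 1 to compound 3 (0.90 log units; beyond the scatter)), and compound 3 has the lowest of the three numbers. No measurement shown explains either step.

The compounds shown leave open whether the gain comes from the hydroxyl or from the cyclohexyl ring. They also leave open how an amine or a carboxylic acid in place of that hydroxyl would read.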